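The source may report more compounds than this note shows. Statements on the series, on what has been measured and on what is new or still open speak of the compounds shown alone.

In a functional assay on MCF7 cells (Homo sapiens), tested at 2.5 uM (on this read-out lower numbers stand for a stronger effect and higher numbers for a weaker effect at the one concentration tested), compound 1 `C=CCOc1c(C)c(C)c2c(c1C)CCC(C)(COc1ccc(/C=C3\SC(=O)NC3=O)cc1OCC)O2` gives 107%, compound 2 `COc1cc(/C=C2\SC(=O)NC2=O)ccc1OCC1(C)CCc2c(C)c(OCC=C(C)C)c(C)c(C)c2O1` gives 95%, and compound 3 `C=CCOc1c(C)c(C)c2c(c1C)CCC(C)(COc1ccc(/C=C3\SC(=O)NC3=O)cc1OC)O2` gives 34%, the lowest of the three numbers and thus the strongest effect seen so far. Both neighbours sit well above it: the step of a number 73 percentage points lower from compound 1 to compound 3 (beyond the scatter) and the step of a number 61 percentage points lower from compound 2 to compound 3 (beyond the scatter) were each large, so each change toward compound 3 strengthened the effect beyond the scatter.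

Compound 4 `C=CCOc1c(C)c(C)c2c(c1C)CCC(C)(COc1ccc(/C=C3\SC(=O)NC3=O)cc1C)O2` is reached from compound 3 by a change at the same place that the first of those steps touched: methyl in place of methoxy on an aromatic carbon. The earlier step at this place shrank the group there and lowered the number sharply; the new step shrinks it further and removes the oxygen. Going by the values given here, no measured pair shows what dropping that oxygen does, so the direction is open. Because the step of a number 73 percentage points lower from compound 1 to compound 3 (beyond the scatter) already rewarded a smaller group here, a number near compound 3 is plausible, but a loss is equally conceivable. The expected step is a number 21 percentage points higher from compound 3 to compound 4 (beyond the scatter), and compound 4 is expected to give about 55%, within 20% to 95%.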

Compound 4, a percentage reported as activity, at one concentration (the size of the read-out at that concentration, not a potency): 84%
Compound 4: middle estimate off by 29 percentage points, on the low side; the range from low to high includes it.
By their numbers in this assay, from the lowest: compound 3; then compound 4; then compound 2; then compound 1.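

Shrinking the group at this position does not keep strengthening the effect: in this assay, replacing methoxy with methyl gives a number 50 percentage points higher from compound 3 to compound 4 (beyond the scatter). Replacing ethoxy with methyl gives a number 23 percentage points lower from compound 1 to compound 4 (beyond the scatter), so methyl falls between the two other groups, and the smallest of the three does not give the lowest number. Nothing available explains this order.

The compounds shown leave open whether the oxygen of methoxy matters in itself or whether another group of similar size could match it, as a hydroxy group, a chlorine atom or a fluorine atom at this aromatic carbon might show. They also leave open how a longer chain such as propoxy would compare with ethoxy.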